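Methyl on the ring nitrogen: a large loss, tested again

The compounds below may be only part of what the source reports. "The series", "measured", "known", "first", "only" and "open" are said of these compounds alone.

Measured so far in an assay on isolated protein for inhibition of ribosomal protein S6 kinase alpha-5 (Homo sapiens), read by mobility shift assay, tested at 30 uM; a lower number here means less inhibition, a higher number more inhibition at the concentration tested (going by the name of the read-out):
compound 1 `COc1ccc(-c2cc3[nH]nc(N)c3c(=O)[nH]2)cc1` gives 62%
compound 2 `Cc1cc2[nH]nc(N)c2c(N2CCCCC2)n1` gives 87%
compound 3 `COc1ccc(-c2cc3c(c(N)nn3C)c(=O)[nH]2)cc1` gives 9%

Compound 2 stands highest of the three in this assay, and its steps to compound 1 and to compound 3 both lie beyond the scatter. Compound 1 and compound 2 rest on different cores; how the two cores differ is not broken down here.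

Compound 3 differs from compound 1 in one place, (methyl in place of hydrogen on an aromatic nitrogen). The step was a number 53 percentage points lower from compound 1 to compound 3 (beyond the scatter).

Compound 4 `Cc1cc2c(c(N)nn2C)c(N2CCCCC2)n1` is not yet measured. It differs from compound 2 in the same place and in the same way, (methyl in place of hydrogen on an aromatic nitrogen), so the change is the same change on the other core. Because the step from compound 1 to compound 3 was a number 53 percentage points lower from compound 1 to compound 3 (beyond the scatter), a step of a similar size is expected here, resting on that single earlier pair. Compound 4 is therefore estimated at 34% in this assay, between 10% and 60%, which means an expected step of a number 53 percentage points lower from compound 2 to compound 4 (beyond the scatter).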

Compound 4, a percentage reported as inhibition, at one concentration (the size of the read-out at that concentration, not a potency): 7%
For compound 4 the middle estimate is 27 percentage points above the measured one; the measured number lies below the stated range.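

In this assay, methyl in place of hydrogen on an aromatic nitrogen again brought a large loss, the new step being a number 80 percentage points lower from compound 2 to compound 4 (beyond the scatter). The direction of the change carried over from one core to the other, but its size did not: the same change on two cores in this assay, a number 53 percentage points lower (beyond the scatter) from compound 1 to compound 3 and a number 80 percentage points lower (beyond the scatter) from compound 2 to compound 4, 27 percentage points apart, beyond the scatter of two such steps. Two pairs in one assay do not show how the change would behave on any further core, and they give no reason for the difference in size.

The compounds shown leave open whether a longer chain such as ethyl on the aromatic nitrogen would track methyl. They also leave open whether a hydroxyethyl group there would give back any of the inhibition.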